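The source may hold more compounds than are shown below. What is called first, only, known or untested is meant among the compounds shown, and "the series" means these compounds.

Measured so far:
- compound 1, `COc1ccc2cc([C@](O)(c3c[nH]cn3)C(C)C)ccc2c1`: 21 nM
- compound 2, `CNC(=O)c1ccc2cc(C(O)(c3c[nH]cn3)C(C)C)ccc2c1C`: 200 nM
- compound 3, `CNC(=O)Nc1ccc2cc(C(O)(c3c[nH]cn3)C(C)C)ccc2c1`: 11 nM

All three share a core and were tested in an assay on microsomes from Testis (strain Sprague-Dawley) for inhibition of steroid 17-alpha-hydroxylase/17,20 lyase (Rattus norvegicus); a higher number here means a weaker inhibitor, a lower number a stronger inhibitor. Compound 3 carries the lowest of the three numbers. Its gap to compound 1 lies within the usual scatter, so the two cannot be told apart; its gap to compound 2 lies beyond the scatter, so compound 2 is clearly the weaker inhibitor of that pair.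

The next compound, compound 4, `CC(C)NC(=O)c1ccc2cc(C(O)(c3c[nH]cn3)C(C)C)ccc2c1`, is not yet measured. It differs from compound 3 at one spot: isopropylcarbamoyl in place of (methylcarbamoyl)amino on an aromatic carbon

Among the compounds with values here, no measured pair shows this exact change, so the step from compound 3 to compound 4 in this assay can only be guessed. Compound 2, which also carries a carbon-linked carbamoyl group on the core, gives 200 nM, a markedly higher number than compound 3. The step for compound 4 is therefore expected to go toward a higher number, of modest size, estimated as a 3.6-fold higher number from compound 3 to compound 4 (0.56 log units; beyond the scatter). Compound 4 is estimated at 40 nM, with a range from 10 nM to 160 nM.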

Compound 4, half-maximal inhibitory concentration: 12 nM
The estimate for compound 4 lay 3.3-fold (0.52 log units) above the measured number; measured number inside the range.
By their numbers in this assay, from the lowest: compounds 3, 4 and 1 (each within the scatter of the next); then compound 2.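

In this assay, putting isopropylcarbamoyl in place of (methylcarbamoyl)amino on this aromatic carbon gives a 1.1-fold higher number from compound 3 to compound 4 (0.04 log units; within the scatter) and so leaves the two compounds indistinguishable. The change therefore shows that this position can carry either of these two groups, even though the entering group has one hydrogen-bond donor where the leaving group has 2, and it joins the ring through its carbonyl carbon, not through a nitrogen. Nothing measured here explains this result. Compound 2 differs from compound 4 in more than one place, so its higher number cannot be traced to any single change. As far as these compounds go, it also remains open how an amine, a carboxylic acid or a longer chain on the amide nitrogen would fare on this aromatic carbon.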